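This account rests on a few compounds, and the source may have more. Where it says the series, first, only, none or still open, it means among the compounds named here.

In a functional assay on cells (Renal cancer cell line, Homo sapiens) for cytotoxicity, read by sulforhodamine B assay, with a stated time of 48 h (on this read-out higher numbers stand for weaker inhibition of growth and lower numbers for stronger inhibition of growth), compound 3 `COc1ccc2c(c1)/C(=C\c1c(OC)nc3sc(C)cn13)C(=O)N2` gives 61800 nM, which lies within the scatter of compound 1 `COc1cc2c(cc1C)NC(=O)/C2=C/c1c(OC)nc2sc(C)cn12` at 58900 nM and of compound 2 `O=C1Nc2ccccc2C1=Cc1c(-c2ccncc2)nc2sccn12` at 73200 nM. Compound 4 `COc1nc2sc(C)cn2c1/C=C1/C(=O)Nc2ccc(O)cc21` differs from compound 3 by hydrogen in place of methyl on an oxygen on an aromatic ring, that is, methoxy to hydroxy. Going by the values given here, the one measured step, a 1.0-fold higher number from compound 1 to compound 3 (0.02 log units; within the scatter), is hydrogen in place of methyl on an aromatic carbon, not on an oxygen, so it offers only loose guidance. With that single precedent, no step beyond the scatter is expected in this assay, in either direction. The expected result is a 1.0-fold lower number from compound 3 to compound 4 (0.01 log units; within the scatter). The estimate for compound 4 is 60000 nM, with an expected range of 35000 nM to 95000 nM.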

Compound 4, concentration for total growth inhibition: 79400 nM
Estimate against measurement, compound 4: 1.3-fold (0.12 log units) below; low and high end bracket the measured number.
By their numbers in this assay, from the lowest: compounds 1, 3, 2 and 4 (each within the scatter of the next).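

In this assay the change on the oxygen on an aromatic ring, methoxy to hydroxy, gives a 1.3-fold higher number from compound 3 to compound 4 (0.11 log units; within the scatter) and so stays within the scatter. With a 1.0-fold higher number from compound 1 to compound 3 (0.02 log units; within the scatter) on an aromatic carbon, hydrogen in place of methyl now stands within the scatter on an oxygen as well. Nothing at hand explains this step. Open, from the compounds shown here alone, is whether ethoxy or an amine in place of the hydroxy of compound 4 would also stay within the scatter, and whether the same holds in other cell lines.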